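Aminoalkyl Chain Replaces Benzyl on the Shared Core

The source may report more compounds than this note shows. Statements on the series, on what has been measured and on what is new or still open speak of the compounds shown alone.

Compound 1 `O=C(NCc1ccc(F)cc1)c1nc(Br)c2cccnc2c1NCCCNc1c(C(=O)NCc2ccc(F)cc2)nc(Br)c2cccnc12`: in a functional assay on MDA-MB-435 cells (Homo sapiens) for cytotoxicity, read by MTT assay, with a stated time of 72 h (on this read-out higher numbers stand for weaker inhibition and lower numbers for stronger inhibition), compound 1 gives > 20000 nM, which is a limit of the assay.
Compound 2 `O=C(NCc1ccc(F)cc1)c1nc(Br)c2cccnc2c1NCc1ccccc1`: in this assay compound 2 gives > 20000 nM, also a limit of the assay.
Compound 3 `N[C@H]1CC[C@H](Nc2c(C(=O)NCc3ccccc3)nc(Br)c3cccnc23)CC1`: in this assay compound 3 gives 7000 nM.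

Compound 2 therefore stands at the limit of > 20000 nM in this assay, at which 2 of the 3 values shown sit, with no number of its own. For the measured compounds named here, the only compound with a numerical result is compound 3, and compound 3 carries a free amine on its saturated ring.

Compound 4 `NCCCCCCNc1c(C(=O)NCc2ccc(F)cc2)nc(Br)c2cccnc12` differs from compound 2 by 5-aminopentyl in place of phenyl on a saturated chain carbon bound to a nitrogen on an aromatic ring. Going by the values given here, no pair of measured compounds shows this exact change, so the size of the step has to be guessed. Among the compounds with values here, the entering chain ends in an amine, and the one amine-bearing compound here, compound 3, is the one that gives a number, 7000 nM. On that basis a step toward stronger inhibition is expected in this assay, roughly an at least 2.5-fold lower number from compound 2 to compound 4 (0.39 log units; beyond the scatter), though a result that again stops at the limit remains possible. Compound 4 is estimated at 8000 nM, within 3000 nM to 25000 nM.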

Compound 4, half-maximal inhibitory concentration: 6000 nM
Compound 4: middle estimate off by 1.3-fold (0.12 log units), on the high side, within the range that was stated.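

On the shared core, the group at this position clearly matters in this assay: 5-aminopentyl in place of phenyl on a saturated chain carbon bound to a nitrogen on an aromatic ring gives an at least 3.3-fold lower number from compound 2 to compound 4 (0.52 log units; beyond the scatter). The value of compound 2 is a limit of the assay and not a number, so this step has a minimum size but no exact one: the limit of > 20000 nM in this assay, at which 2 of the 4 values shown sit. This is the only step shown between two compounds that differ in one place, and it links the open chain ending in an amine to a measurable value.

The change removes a ring and brings in an amine together, and the compounds shown cannot separate these two parts. A plain hexyl chain, a shorter or longer chain ending in an amine, or a chain ending in a carboxylic acid would bear on that question.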